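Cytotoxicity limits and a sulfonyl swap on the nitrogen

This account rests on a few compounds, and the source may have more. Where it says the series, first, only, none or still open, it means among the compounds named here.

Compound 1 `COc1ccc([C@H]2CC(=O)N(c3cccc(C(F)(F)F)c3)C2)cc1OC1CCCC1`: > 10000 nM
Compound 2 `COc1ccc([C@H]2CC(=O)N(c3cccc(NCc4ccoc4)c3)C2)cc1OC1CCCC1`: > 10000 nM
Compound 3 `COc1ccc([C@H]2CC(=O)N(c3cccc(NC(=O)C(C)=O)c3)C2)cc1OC1CCCC1`: > 10000 nM

Each entry above is a limit and not a number, as the summary shows: the limit of > 10000 nM in this assay, at which 3 of the 3 values shown sit. In a functional assay on HEK293 cells (Homo sapiens) for cytotoxicity (on this read-out higher numbers stand for lower toxicity in this test and lower numbers for higher toxicity in this test), compound 3 gives > 10000 nM, which is a limit.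

The next structure is compound 4 `COc1ccc([C@H]2CC(=O)N(c3cccc(NS(=O)(=O)c4ccccc4F)c3)C2)cc1OC1CCCC1`. It differs by (2-fluorophenyl)sulfonyl in place of acetylcarbonyl on a nitrogen on an aromatic ring. In words, (2-fluorophenyl)sulfonyl stands in place of acetylcarbonyl on a nitrogen on an aromatic ring.

Within the data shown here, three measured steps bear on this change. The closest is a step that the two limits leave unreadable from compound 2 to compound 3, which exchanges the group on the same nitrogen. The other two, a step that the two limits leave unreadable from compound 1 to compound 2 and a step that the two limits leave unreadable from compound 1 to compound 3, replace trifluoromethyl. None of the three has a readable size, so they give no direction and no measured size for the new change. In this assay no shift beyond the usual scatter is therefore expected, and a further limit is the likeliest report. The expected step is a step that the limit leaves unreadable from compound 3 to compound 4. Compound 4 is estimated at 15000 nM, with an expected range of 6000 nM to 40000 nM.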

Compound 4, half-maximal cytotoxic concentration: > 10000 nM
Compound 4: only a limit was reported (the forecaster's own chance of this, stated with the estimate: 75%); the middle value lies beyond the limit too.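

In this assay compound 4 gives > 10000 nM, which is a limit. No step from compound 1, compound 2 or compound 3 to compound 4 can be read: the limit of > 10000 nM in this assay, at which 4 of the 4 values shown sit.

The compounds shown leave open whether any of these groups shifts cytotoxicity, and by how much.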